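The source may report more compounds than this note shows. Statements on the series, on what has been measured and on what is new or still open speak of the compounds shown alone.

Working notes on the series.

Of the compounds shown here, three of the shared core have been measured in a functional assay on A2780 cells (Homo sapiens) for antiproliferative activity, read by fluorescence, with a stated time of 72 h; on this read-out higher numbers stand for weaker inhibition and lower numbers for stronger inhibition. Compound 1 `CC1(C)c2[nH]nc(NC(=O)c3ccc(F)cc3)c2CN1C(=O)C1CCN(C2CC2)CC1` gives 380 nM in this assay. Compound 2 `CN1CCC(C(=O)N2Cc3c(NC(=O)Nc4cccc(F)c4)n[nH]c3C2(C)C)CC1` gives 350 nM in this assay. Compound 3 `CC(C)(C)C(=O)N1Cc2c(NC(=O)c3cccnc3)n[nH]c2C1(C)C` gives 690 nM in this assay. For the measured compounds named here, the three values all lie within the usual scatter of one another, so compound 2 is not separated from either compound 1 or compound 3 on this assay; no compound can be called stronger or weaker than the others from these numbers. Going by the values given here, none of the three pairs differs in a single place, so no step between measured compounds is available.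

Compound 4 `CN1CCC(C(=O)N2Cc3c(NC(=O)C4CC4)n[nH]c3C2(C)C)CC1` is the next compound to be measured in this assay. It differs from compound 2 in one place: cyclopropyl in place of (3-fluorophenyl)amino on a carbonyl carbon. The aromatic ring of the leaving group and its hydrogen-bond donor are gone, and a small carbon ring takes the place.

Among the compounds with values here, no measured pair isolates this change, so the expectation rests on the compounds as a whole. Every measured compound carries a six-membered aromatic ring at this position, and all of them fall within a narrow band of values; removing that ring is expected to shift the number upward, toward weaker inhibition, by a step of a 4.3-fold higher number from compound 2 to compound 4 (0.63 log units; beyond the scatter). Compound 4 is therefore estimated at 1500 nM in this assay, with a range from 400 nM to 6000 nM.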

Compound 4, half-maximal inhibitory concentration: 1420 nM
Beside the measured number, compound 4's estimate is 1.1-fold (0.02 log units) above it, within the range that was stated.
By their numbers in this assay, from the lowest: compounds 2, 1 and 3 (each within the scatter of the next); then compound 4.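

In this assay, cyclopropyl in place of (3-fluorophenyl)amino on a carbonyl carbon gives a 4.1-fold higher number from compound 2 to compound 4 (0.61 log units; beyond the scatter). For the compounds shown here, this modest step is the first to involve a single change and the first to lie beyond the scatter, so the group at this position does affect the number, a point the earlier compounds could not settle. The change removes one six-membered aromatic ring of carbon only and one hydrogen-bond donor together, yet inhibition is weakened rather than abolished, with compound 4 still giving 1420 nM, and nothing available bears on the reason for the shift.

The ring and the donor leave in the same step, so the compounds shown do not divide the step between them or show how much depends on the size of the group. Going by these compounds, a cyclopropylamino group on the same carbonyl carbon would retain a hydrogen-bond donor with the small ring, while an unsubstituted phenyl group there would retain an aromatic ring without that donor, and these two groups remain open.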